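The source may hold more compounds than are shown below. What is called first, only, known or untested is meant among the compounds shown, and "the series" means these compounds.

Working notes on the series. The shared core is that of compound 3, `Cc1cc(=O)n(-c2ccc(F)cc2)nc1C(=O)Nc1ccc(Oc2ncnc3sccc23)c(F)c1`, and the compounds differ only in the aryl group on the aromatic nitrogen. In a functional assay on A549 cells (Homo sapiens) for cytotoxicity, read by MTT assay, with a stated time of 72 h (on this read-out lower numbers stand for stronger inhibition and higher numbers for weaker inhibition), compound 3 gives 2620 nM. Compound 1, `Cc1cc(=O)n(-c2ccc(Br)cc2F)nc1C(=O)Nc1ccc(Oc2ncnc3sccc23)c(F)c1`, carries 4-bromo-2-fluorophenyl there, and in this assay compound 1 gives 11500 nM. Compound 2, `Cc1cc(=O)n(-c2ccccc2OC(F)(F)F)nc1C(=O)Nc1ccc(Oc2ncnc3sccc23)c(F)c1`, carries 2-(trifluoromethoxy)phenyl. For compound 2 the result in this assay is a limit, > 40000 nM. Compound 2 therefore sits at the limit of > 40000 nM in this assay, at which 1 of the 3 values shown sits.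

The step of a 4.4-fold lower number from compound 1 to compound 3 (0.64 log units; beyond the scatter) is modest, the step of an at least 15-fold lower number from compound 2 to compound 3 (1.18 log units; beyond the scatter) is large, and the step of an at least 3.4-fold higher number from compound 1 to compound 2 (0.54 log units; beyond the scatter) is at least modest. Compound 3 thus stands at the lowest of the two numbers in hand, with compound 1 nearest.

Compound 4, `Cc1cc(=O)n(-c2ccc(F)c(F)c2)nc1C(=O)Nc1ccc(Oc2ncnc3sccc23)c(F)c1`, differs from compound 3 by fluoro in place of hydrogen on an aromatic carbon; cut one bond further out, this reads 4-fluorophenyl to 3,4-difluorophenyl. Among the compounds with values here, no measured step alters this single position alone: the steps into compound 3 each change more than one substituent of the aryl ring, so they show the ring is sensitive but give no direction for one added fluoro. The expected step is a 1.1-fold higher number from compound 3 to compound 4 (0.06 log units; within the scatter), within the scatter. Compound 4 is estimated at 3000 nM, range 1200 nM to 8000 nM.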

Compound 4, half-maximal inhibitory concentration: 15700 nM
Compound 4: middle estimate off by 5.2-fold (0.72 log units), on the low side, and the stated range ends below it.
By their numbers in this assay, from the lowest: compound 3; then compounds 1 and 4 (each within the scatter of the next). At a limit, above all of these: compound 2.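

In this assay, within the data shown here, this is the first change confined to a single position of the aryl ring, and it shows that this aromatic carbon, ortho to a fluoro group, is not indifferent to substitution: a 6.0-fold higher number from compound 3 to compound 4 (0.78 log units; beyond the scatter). A single added fluoro thus removes the advantage of compound 3 over the other aryl groups, since 3,4-difluorophenyl and 4-bromo-2-fluorophenyl cannot be told apart in this assay, a 1.4-fold higher number from compound 1 to compound 4 (0.14 log units; within the scatter), while the value of compound 2 remains a limit, so that an at least 2.5-fold lower number from compound 2 to compound 4 (0.40 log units; beyond the scatter) gives only a bound. Nothing measured in the series accounts for the step from hydrogen to fluoro at this position.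

From the compounds shown here alone, whether the loss is particular to fluoro remains open, as a chloro, methyl or methoxy group on the same aromatic carbon would be needed to separate the effect of this atom from that of any substituent there. Going by these compounds, it is equally open how an amine or a carboxylic acid at this position would read out, and whether the same step holds on an aryl ring without the 4-fluoro group.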